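Swapping Bromo for Nitro in a Growth-Inhibition Assay

The compounds below may be only part of what the source reports. "The series", "measured", "known", "first", "only" and "open" are said of these compounds alone.

In a functional assay on U-251 cells (Homo sapiens) for inhibition, read by sulforhodamine B assay, with a stated time of 48 h (a higher number here means a weaker inhibitor of growth, a lower number a stronger inhibitor of growth), compound 1 `CCOC(=O)c1nn(-c2ccc(Cl)cc2)c(-c2ccc([N+](=O)[O-])cc2)c1CNC(C)(C)C` gives > 548000 nM; 340000 nM (2 entries). Compound 2 `CC(C)(C)NCc1c(C(=O)O)nn(-c2ccc(Cl)cc2)c1-c1ccc(Br)cc1` has > 542000 nM as its reading, which is a limit and not a number, and a further entry also gives no single number. Among the compounds with values here, compound 3 `CC(C)(C)NCc1c(C(=O)O)nn(-c2ccc(Cl)cc2)c1-c1ccc([N+](=O)[O-])cc1` takes nitro in place of bromo on an aromatic carbon, para to a large group (nitro in place of bromo on an aromatic carbon) as its one change from compound 2. No measured step sizes this change, so only a small shift, within the scatter and in no firm direction, is expected in this assay here. The expectation rests on compound 1, which also bears a nitro group and whose entries the several entries of compound 1 in this assay, > 548000 nM; 340000 nM (2 entries) include a limit. The expected step of an at least 1.2-fold lower number from compound 2 to compound 3 (0.10 log units; that floor lies within the scatter) stays inside the usual scatter. Compound 3 is estimated at 430000 nM with an expected range from 200000 nM to 700000 nM. Its measurement may also end at a limit of the assay and not at a number.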

Compound 3, concentration for 50% growth inhibition: > 583000 nM
Compound 3 ended at the assay's limit; the forecaster's own chance of this, stated with the estimate: 60%; middle value at least 1.3-fold (0.13 log units) away from the limit.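

In this assay compound 2 reads > 542000 nM, which is a limit of the assay. Compound 3 reads > 583000 nM, also a limit. Within the data shown here, no step between compound 2 and compound 3 can therefore be read. As far as these compounds go, whether nitro in place of bromo changes growth inhibition at all, and in which direction, stays open.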